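A few compounds are considered here, and "the series" means these few. Any claim that something is new, unique, unknown or untested is made for them only; others in the source may bear on it.

Measured so far:
compound 1, `CNC(=O)c1cc(Oc2ccc(NC(=O)c3nn(-c4ccccc4C(F)(F)F)c(=O)cc3C)cc2F)ccn1` — > 40000 nM
compound 2, `Cc1cc(=O)n(-c2ccccc2OC(F)(F)F)nc1C(=O)Nc1ccc(Oc2ncnc3ccsc23)cc1` — 25000 nM
compound 3, `Cc1cc(=O)n(-c2ccccc2OC(F)(F)F)nc1C(=O)Nc1ccc(Oc2ncnc3sccc23)cc1` — 14400 nM

In a functional assay on HepG2 cells (Homo sapiens) for cytotoxicity, read by MTT assay, with a stated time of 72 h (a lower number here means a stronger inhibitor, a higher number a weaker inhibitor), compound 1 gives > 40000 nM, which is a limit of the assay and not a number. Compound 2 gives 25000 nM and compound 3 gives 14400 nM; the two numbers lie within the scatter of one another, as the step of a 1.7-fold lower number from compound 2 to compound 3 (0.24 log units; within the scatter) shows. Compound 4, `Cc1cc(=O)n(-c2ccc(F)cc2)nc1C(=O)Nc1ccc(Oc2ncnc3sccc23)cc1`, differs from compound 3 by 4-fluorophenyl in place of 2-(trifluoromethoxy)phenyl on an aromatic nitrogen. No measured step touches this group: the only step shown concerns a different part of the shared core and was itself within the scatter, so the data give no direction for this change. Compound 4 is therefore expected to give about 15000 nM, with a range of 5000 nM to 40000 nM. The step of a 1.0-fold higher number from compound 3 to compound 4 (0.02 log units; within the scatter) is expected to stay within the scatter.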

Compound 4, half-maximal inhibitory concentration: 6460 nM
Compound 4: the middle estimate sits 2.3-fold (0.37 log units) above what was measured; low and high end bracket the measured number.
By their numbers in this assay, from the lowest: compound 4; then compounds 3 and 2 (each within the scatter of the next). At a limit, above all of these: compound 1.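

In this assay, for the compounds shown here, the group on this aromatic nitrogen proves able to move the number: 4-fluorophenyl in place of 2-(trifluoromethoxy)phenyl gives a modest step beyond the scatter (a 2.2-fold lower number from compound 3 to compound 4 (0.35 log units; beyond the scatter)), whereas the only earlier step lay within the scatter and concerned another part of the molecule. The change alters both the substituent and where it sits on the phenyl ring, so the step cannot be assigned to either alone. Nothing shown accounts for this step. The compounds shown leave open how a plain phenyl group or an alkyl chain on this nitrogen would read.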